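The source may report more compounds than this note shows. Statements on the series, on what has been measured and on what is new or still open speak of the compounds shown alone.

Measured so far in a functional assay on BV-2 cells (Mus musculus) for inhibition, read by Griess assay, with a stated time of 10 min; a higher number here means a weaker inhibitor, a lower number a stronger inhibitor:
compound 1 `COC(=O)[C@]1(O)C[C@@H](O)[C@@H](O)[C@H](OC(=O)/C=C/c2ccc(O)c(O)c2)C1` gives 12100 nM
compound 2 `COC(=O)[C@]1(O)C[C@@H](O)[C@@H](O)[C@H](OC(=O)/C=C\c2ccc(O)c(O)c2)C1` gives 17000 nM
compound 3 `COC(=O)[C@]1(O)C[C@@H](O)[C@@H](OC(=O)/C=C/c2ccc(O)cc2)[C@H](O)C1` gives 45000 nM

Compound 2 stands second highest of the three numbers. Its nearest neighbour is compound 1, with a 1.4-fold higher number from compound 1 to compound 2 (0.15 log units; within the scatter), a step within the scatter that rests only on (the fact that compounds 1 and 2 differ only in the configuration as drawn). Within the data shown here, compound 3 sits furthest from compound 2 and its higher number is beyond the scatter; those two differ in more than one place, so no single step joins them.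

Compound 4 `COC(=O)[C@]1(O)C[C@@H](O)[C@@H](O)[C@H](OC(=O)/C=C\c2ccc(O)cc2)C1` is compound 2 with hydrogen in place of hydroxy on an aromatic carbon. No measured step isolates this change, and the one step shown is within the scatter, so no direction follows from it. The values alone show that compound 3, which carries 4-hydroxyphenyl, gives the highest number. Compound 4 is therefore expected to shift toward a higher number, a 2.1-fold higher number from compound 2 to compound 4 (0.31 log units; beyond the scatter). The estimate for compound 4 is 35000 nM, range 15000 nM to 80000 nM.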

Compound 4, half-maximal inhibitory concentration: 86400 nM
Beside the measured number, compound 4's estimate is 2.5-fold (0.39 log units) below it; measured number above the stated range.
By their numbers in this assay, from the lowest: compounds 1 and 2 (each within the scatter of the next); then compounds 3 and 4 (each within the scatter of the next).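

In this assay, among these compounds, the change from 3,4-dihydroxyphenyl to 4-hydroxyphenyl gives a 5.1-fold higher number from compound 2 to compound 4 (0.71 log units; beyond the scatter) and is the first single-place step beyond the scatter. Among the compounds shown here, the hydroxy ortho to a hydroxy group therefore counts toward inhibition in compound 2, whereas the one earlier step, a change in drawn configuration, stayed within the scatter. Nothing given here supplies a reason for the new step.

On these data alone, whether the same change has a similar effect with the double bond drawn E remains open. Also open, as far as these compounds go, is how a methoxy group, a fluorine or an amine would compare with hydroxy at this position.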